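Swapping Methyl for Nitro at the Assay Limit

This account rests on a few compounds, and the source may have more. Where it says the series, first, only, none or still open, it means among the compounds named here.

In an ADME assay on HaCaT cells (Homo sapiens) for inhibition, read by sulforhodamine B assay, with a stated time of 48 h (on this read-out higher numbers stand for weaker inhibition of growth and lower numbers for stronger inhibition of growth), compound 2 `Cc1ccc(-c2c(CNC(C)(C)C)c(C(=O)O)nn2-c2ccc(Cl)cc2)cc1` gives > 629000 nM as a limit of the assay and not a number. Compound 1 `CC(C)(C)NCc1c(C(=O)O)nn(-c2ccccc2)c1-c1ccc([N+](=O)[O-])cc1` likewise gives > 634000 nM as a limit of the assay. Neither reading therefore supplies a number from which to judge the next change.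

Compound 3 `CC(C)(C)NCc1c(C(=O)O)nn(-c2ccc(Cl)cc2)c1-c1ccc([N+](=O)[O-])cc1` differs from compound 2 by a single substitution, counted as nitro in place of methyl on an aromatic carbon in full: nitro in place of methyl on an aromatic carbon, para to a large group, so that 4-methylphenyl becomes 4-nitrophenyl.

For compound 2 the reading of > 629000 nM remains a limit, so the expected at least 1.0-fold lower number from compound 2 to compound 3 (0.02 log units; that floor lies within the scatter) in this assay is no step beyond the scatter, and no direction is favoured. Compound 3 is estimated at 600000 nM within a range from 300000 nM to 800000 nM and is expected most likely to be reported again as a limit.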

Compound 3, concentration for 50% growth inhibition: > 583000 nM
Compound 3 ended at the assay's limit (the forecaster's own chance of this, stated with the estimate: 85%); the middle value is on the limit's open side.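

In this assay compound 3 gives > 583000 nM, a limit of the assay and not a number. Among these compounds, compound 1 and compound 2 also stand at limits, so no step to compound 3 can be read. On these data alone, whether nitro in place of methyl, or chloro in place of hydrogen, changes growth inhibition stays open.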